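A few compounds are considered here, and "the series" means these few. Any claim that something is new, unique, unknown or untested is made for them only; others in the source may bear on it.

Measured so far:
- compound 1 `COc1ccc(OC)c(/C=C/c2nnc(Nc3ccc(Cl)cc3)o2)c1` — 3290 nM
- compound 2 `COc1ccc(OC)c(/C=C/C(=O)N/N=C/c2ccc(Cl)cc2)c1` — 1490 nM

In a functional assay on ACHN cells (Homo sapiens) for antiproliferative activity, read by sulforhodamine B assay, with a stated time of 48 h (on this read-out lower numbers stand for stronger inhibition of growth and higher numbers for weaker inhibition of growth), compound 2 gives 1490 nM, the lower of the two numbers in hand. Compound 1 gives 3290 nM in this assay, a higher number, and the gap between the two lies beyond the scatter. Among the measured compounds shown here, the two compounds differ in several places at once, so no single-point step is known from the measured pair, and nothing in the data yet calibrates the effect of changing a substituent on the aryl ring.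

The next compound is compound 3 `COc1ccc(OC)c(/C=C/C(=O)N/N=C/c2ccccc2)c1`. It differs from compound 2 in one place: hydrogen in place of chloro on an aromatic carbon. For the measured compounds named here, with no measured step of this kind available, the expectation is a moderate move toward a higher number, a 2.0-fold higher number from compound 2 to compound 3 (0.30 log units; within the scatter), with a range kept wide enough to cover no change at all as well as a clearer loss. On that basis compound 3 is expected to give about 3000 nM in this assay, within a range from 1200 nM to 8000 nM.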

Compound 3, concentration for 50% growth inhibition: 9660 nM
Estimate against measurement, compound 3: 3.2-fold (0.51 log units) below; measured number above the stated range.
By their numbers in this assay, from the lowest: compound 2; then compound 1; then compound 3.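

In this assay, among the compounds shown here, hydrogen in place of chloro gives a 6.5-fold higher number from compound 2 to compound 3 (0.81 log units; beyond the scatter), the first single-point step and the first calibration of a change on this aryl ring. This place on the six-membered aromatic ring of carbon only, para to a large group, therefore responds clearly to its substituent: the exchange of one chlorine atom for a hydrogen atom, with no ring, hydrogen-bond donor, hydrogen-bond acceptor or net charge entering or leaving, moves the number beyond the scatter. Nothing available bears on the origin of this step, and the data show only its size and direction.

From the compounds shown here alone, with only chloro and hydrogen compared at this place, it remains open whether fluoro, bromo, methoxy or an amine would fall nearer compound 2 or compound 3, or beyond either. Going by these compounds, the step is also known only on the core shared by compound 2 and compound 3, so it remains open whether the same exchange would have a similar effect on the core of compound 1.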